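The compounds below may be only part of what the source reports. "The series", "measured", "known", "first", "only" and "open" are said of these compounds alone.

Measured so far, all in a functional assay on HeLa cells (Homo sapiens) for cytotoxicity, read by MTT assay, with a stated time of 24 h; a lower number here means a stronger inhibitor, a higher number a weaker inhibitor:
- Compound 1 `C=CC1=C(C(=O)NCc2ccccc2)C(c2ccc(OC)c(OC)c2)OC1` gives > 100000 nM, which is a limit of the assay and not a number.
- Compound 2 `C=CC1=C(C(=O)NCc2ccccc2)C(c2ccc(OC)cc2)OC1` gives > 100000 nM, again a limit rather than a number.
- Compound 3 `C=CC1=C(C(=O)NC(C)(C)C)C(c2ccc(Cl)c(Cl)c2)OC1` gives > 100000 nM, also a limit.

Compound 1 therefore stands only at the limit, where every value shown sits (the limit of > 100000 nM in this assay, at which 3 of the 3 values shown sit). The one step among these compounds, a step that the two limits leave unreadable from compound 1 to compound 2, cannot be read in size, because both ends are limits.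

Compound 4 `C=CC1=C(C(=O)NCCC)C(c2ccc(OC)c(OC)c2)OC1` has not been measured. It differs from compound 1 by ethyl in place of phenyl on a saturated chain carbon bound to an amide-type nitrogen, that is, benzyl to propyl, or benzylamino to propylamino. Among the compounds with values here, no measured step touches the amide substituent, so nothing here says how large a step to expect, in which direction, or whether it clears the scatter. What the data do give is that three compounds with different aromatic substituents and amide groups all sit at the limit.

So the step that the limit leaves unreadable from compound 1 to compound 4 is expected to be small or absent. Compound 4 is estimated at 150000 nM, within 50000 nM to 1000000 nM, and most likely it too is reported only as a limit.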

Compound 4, half-maximal inhibitory concentration: > 100000 nM
Compound 4: a limit, no number (the forecaster's own chance of this, stated with the estimate: 85%); the middle value does not contradict the limit.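

Compound 1 and compound 4 both stand at a limit and not at a number, so the step from benzyl to propyl cannot be read in size: the limit of > 100000 nM in this assay, at which 4 of the 4 values shown sit. The compounds shown leave open which change, if any, would give a measurable value in this assay.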